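The compounds below may be only part of what the source reports. "The series", "measured", "known", "first", "only" and "open" are said of these compounds alone.

Measured so far in an ADME assay on MRC5 cells (Homo sapiens) for inhibition, with a stated time of 72 h; on this read-out lower numbers stand for an effect already at smaller amounts and higher numbers for an effect only at larger amounts of compound:
- compound 1 `COc1cccc(OC)c1C(=O)Nc1c[nH]nc1C(=O)NC1CCCCCC1` gives 42000 nM
- compound 2 `CO[C@H]1CC[C@H](NC(=O)c2n[nH]cc2NC(=O)c2ccccc2C(F)(F)F)CC1` gives 3300 nM
- compound 3 `COc1cccc(OC)c1C(=O)Nc1c[nH]nc1C(=O)NC1CCN(C(=O)OC(C)(C)C)CC1` is reported only as a limit of this assay, not as a number: > 50000 nM, see the limit of > 50000 nM in this assay, at which 1 of the 3 values shown sits.

Among the two numbers shown, compound 2 stands lowest; compound 1 sits at the higher number, and the gap between the two is beyond the usual scatter. Compound 3 is excluded from this ordering since only a limit is known for it.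

The next compound, compound 4 `CO[C@H]1CC[C@H](NC(=O)c2n[nH]cc2NC(=O)c2ccccc2F)CC1`, keeps the whole of compound 2 apart from one change: fluoro in place of trifluoromethyl on an aromatic carbon. Going by the values given here, no pair of measured compounds shows this same change, so the size of the step has to be guessed from compound 2 alone and from the spread of the other values.

The expectation for this assay is a moderate step toward higher numbers from compound 2 to compound 4, a 2.4-fold higher number from compound 2 to compound 4 (0.38 log units; beyond the scatter), though a step within the scatter cannot be ruled out. Compound 4 is therefore estimated at 8000 nM, with a range from 3000 nM to 25000 nM.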

Compound 4, half-maximal effective concentration: 1000 nM
Compound 4: the middle estimate sits 8.0-fold (0.90 log units) above what was measured; measured number below the stated range.
By their numbers in this assay, from the lowest: compound 4; then compound 2; then compound 1. At a limit, above all of these: compound 3.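

In this assay, going by these compounds alone, the place ortho to a large group on the aromatic ring is the first position with a readable step: a 3.3-fold lower number from compound 2 to compound 4 (0.52 log units; beyond the scatter), for fluoro in place of trifluoromethyl. All else in compound 2 is kept, so this one substituent is enough to shift the number on this read-out, and the group with 1 heavy atom goes with the lower number, against 4 heavy atoms for trifluoromethyl. Nothing measured on these compounds accounts for the size or direction of this step.

From the compounds shown here alone, a single pair sets no trend, so it stays open whether the number follows the size of the group here or would respond differently to chloro, methoxy or a nitrile at the same place. Also open, going by these compounds, is whether the same change gives a similar step with a different amide substituent in place of the methoxy-bearing ring of compound 2.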